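Swapping a fluorinated carbinol for a sulfoximine on the shared core

The compounds below may be only part of what the source reports. "The series", "measured", "known", "first", "only" and "open" are said of these compounds alone.

Compound 1 `CC#C[C@H]1CN(S(=O)(=O)c2ccc(N)nc2)CCN1c1ccc([C@@](O)(CO)C(F)(F)F)cc1` gives 53 mL.min-1.g-1 in an ADME assay (liver) for metabolic stability, with Liver microsome (Rattus norvegicus) as the target, using microsomes and NADPH, with a stated time of 30 min; on this read-out higher numbers stand for fast clearance and lower numbers for slow clearance. Compound 2 `CC#C[C@H]1CN(S(=O)(=O)c2ccc(N)nc2)CCN1c1ccc(C(O)(COC)C(F)(F)F)cc1` gives 93 mL.min-1.g-1 in this assay.

Compound 2 has the higher of the two numbers, yet the step of a 1.8-fold higher number from compound 1 to compound 2 (0.24 log units; within the scatter) lies within the scatter, so the two compounds cannot be separated on this read-out. Compound 3 `CC#C[C@H]1CN(S(=O)(=O)c2ccc(N)nc2)CCN1c1ccc(S(C)(=N)=O)cc1` changes the same position again: a group of 4 heavy atoms (1 carbon, 1 nitrogen, 1 oxygen, 1 sulfur; no ring) in place of a group of 9 heavy atoms (4 carbon, 2 oxygen, 3 fluorine; no ring), on an aromatic carbon. Among the compounds with values here, the only measured step, a 1.8-fold higher number from compound 1 to compound 2 (0.24 log units; within the scatter), also reworked this group and left the clearance essentially unchanged, but the entering group resembles nothing yet measured, so that step is a weak guide. On this evidence no step beyond the scatter is expected, with wide uncertainty in either direction. Compound 3 is estimated at 60 mL.min-1.g-1, with a range from 20 mL.min-1.g-1 to 180 mL.min-1.g-1. For compound 3 the expected step is a 1.6-fold lower number from compound 2 to compound 3 (0.19 log units; within the scatter).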

Compound 3, intrinsic clearance in microsomes: < 14 mL.min-1.g-1
Compound 3: only a limit was reported (the forecaster's own chance of this, stated with the estimate: 5%); at least 4.2-fold (0.63 log units) between middle value and limit.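

Replacing the fluorinated carbinol with the sulfoximine on the aromatic carbon gives an at least 6.6-fold lower number from compound 2 to compound 3 (0.82 log units; beyond the scatter), and starting from the other carbinol it gives an at least 3.7-fold lower number from compound 1 to compound 3 (0.57 log units; beyond the scatter). Clearance in this assay therefore does respond to the group at this position, which the earlier pair could not show, since a 1.8-fold higher number from compound 1 to compound 2 (0.24 log units; within the scatter). The result for compound 3 is a limit of the assay and not a number: the limit of < 14 mL.min-1.g-1 in this assay, at which 1 of the 3 values shown sits.

The compounds shown do not tell whether the lower number goes with the sulfoximine itself or simply with the loss of the trifluoromethyl carbinol, since both happen in the same step. A methyl sulfone or a primary amide in the same place would help to separate these two readings.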